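A few compounds are considered here, and "the series" means these few. Any claim that something is new, unique, unknown or untested is made for them only; others in the source may bear on it.

Measured compounds and their values:

Compound 1, `CCOC(=O)c1ccc(-c2ccc(OCC)cc2)[nH]1`: 44%
Compound 2, `CCOC(=O)c1cccc(-c2ccc(CN3CCCC3)cc2)c1`: 33%
Compound 3, `CCOc1ccc(-c2ccccc2)cc1`: 35%

All three numbers come from an assay on COS-7 cells for inhibition of patatin-like phospholipase domain-containing protein 2 (Mus musculus), tested at 200 uM; a lower number here means less inhibition, a higher number more inhibition at the concentration tested (going by the name of the read-out). Compound 3 gives a reading that lies within the usual scatter of both of the others, so none of the three can be said to inhibit more or less than another on these numbers, and no ordering can be drawn from them.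

The next compound, compound 4, is `CCOc1ccc(-c2cccc(C(=O)N3CCCC3)c2)cc1`. It keeps the whole of compound 3 and differs in one place: (pyrrolidin-1-yl)carbonyl in place of hydrogen on an aromatic carbon. Compound 2 carries a pyrrolidine ring on its own core as well, joined through a methylene rather than a carbonyl, and its reading is close to that of compound 3.

For the measured compounds named here, no measured pair shows what such a change does here, so the size of the step in this assay has to be guessed. The expectation is a small step upward from compound 3 to compound 4, of about a number 5 percentage points higher from compound 3 to compound 4 (within the scatter), which may well stay within the scatter. Compound 4 is therefore estimated to give 40%, with a likely range from 20% to 60%.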

Compound 4, a percentage reported as inhibition, at one concentration (the size of the read-out at that concentration, not a potency): 53%
Beside the measured number, compound 4's estimate is 13 percentage points below it; the measured number falls inside the stated range.
By their numbers in this assay, from the lowest: compounds 2, 3, 1 and 4 (each within the scatter of the next, the first and the last beyond it).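

In this assay, for the compounds shown here, placing (pyrrolidin-1-yl)carbonyl on an aromatic carbon, meta to a group of 9 heavy atoms, gives a number 18 percentage points higher from compound 3 to compound 4 (beyond the scatter) and is the first step in this set that can be read as a real change and not as scatter. This position therefore takes a group of 7 heavy atoms, with its five-membered non-aromatic ring, and the reading goes up and does not fall away, which compound 3 alone could not show. Nothing measured here says why the reading rises, and no cause can be given for it.

This is a single step at one place, read at one concentration, so it gives the size of a reading and not a potency, and it does not separate what the carbonyl contributes from what the pyrrolidine ring contributes. Open questions are whether a carboxylic acid, a simple dimethylamide or a piperidine amide at the same carbon would give a similar reading, and whether the same (pyrrolidin-1-yl)carbonyl would do so on another carbon of that ring.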